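Swapping the aromatic substituent on a shared core

The source may report more compounds than this note shows. Statements on the series, on what has been measured and on what is new or still open speak of the compounds shown alone.

Of the compounds shown here, three built on one shared core have been measured in an assay on HEK293 cells for activation of Kir3.1/Kir3.2 (Homo sapiens), read by thallium flux; on this read-out lower numbers stand for smaller maximal responses and higher numbers for larger maximal responses. Compound 1 `Cc1cc(NC(=O)Cn2nnc(-c3ccc(Cl)c(Cl)c3)n2)n(C2CCCCC2)n1` bears a 3,4-dichlorophenyl group and gives 84%. Compound 2 `Cc1cc(NC(=O)Cn2nnc(-c3ccnc(F)c3)n2)n(C2CCCCC2)n1` carries a 2-fluoropyridin-4-yl group in its place and gives 95%, so that a number 11 percentage points higher from compound 1 to compound 2 (beyond the scatter). Compound 3 `Cc1cc(NC(=O)Cn2nnc(-c3cccc(F)n3)n2)n(C2CCCCC2)n1`, with a 6-fluoropyridin-2-yl group, is reported only as a limit of the assay, > 83%. For that reason the steps a step that the limit leaves unreadable from compound 1 to compound 3 and a step that the limit leaves unreadable from compound 2 to compound 3 cannot be sized; the limit of > 83% in this assay, at which 1 of the 3 values shown sits, marks where this limit sits.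

Compound 4 `COc1cccc(-c2nnn(CC(=O)Nc3cc(C)nn3C3CCCCC3)n2)c1` differs from compound 3 by the change (3-methoxyphenyl in place of 6-fluoropyridin-2-yl on an aromatic carbon). For the measured compounds named here, no measured step covers this exchange. Going by the values given here, the only readable step of the same kind, an exchange of the aromatic group at this position, is a number 11 percentage points higher from compound 1 to compound 2 (beyond the scatter), and it is modest. For compound 3 the limit leaves its own starting point open. The step that the limit leaves unreadable from compound 3 to compound 4 is therefore expected to be small. Compound 4 is estimated at 86%, with a range from 70% to 100%.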

Compound 4, largest response reached (Emax), in percent of the reference or control that the assay uses: 76%
Compound 4: middle estimate off by 10 percentage points, on the high side; the range from low to high includes it.
By their numbers in this assay, from the lowest: compounds 4 and 1 (each within the scatter of the next); then compound 2.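

The 3-methoxyphenyl group shows that the aromatic group on this carbon can also lower the response in this assay: the exchange gives a number 19 percentage points lower from compound 2 to compound 4 (beyond the scatter). Against the 3,4-dichlorophenyl group the outcome is a number 8 percentage points lower from compound 1 to compound 4 (within the scatter), which leaves compound 2 as the only one set apart among the values that are plain numbers. Compound 3 stands only as a limit, the steps to it from the other two groups cannot be read, and the remaining step, a number at least 7 percentage points lower from compound 3 to compound 4 (that floor lies within the scatter), settles little: the limit of > 83% in this assay, at which 1 of the 4 values shown sits.

The compounds shown do not separate the contribution of the ring nitrogen from that of the fluorine in compound 2. They also leave open how an unsubstituted phenyl group, or a phenyl ring carrying a carboxylic acid, would read at this place.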